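This account rests on a few compounds, and the source may have more. Where it says the series, first, only, none or still open, it means among the compounds named here.

Four compounds of one series are in hand. Compound 1 `CCC(C)NC(=C\C(=O)/C=C/c1ccc(O)c(OC)c1)/C=C/c1ccc(O)c(OC)c1` and compound 2 `COc1cc(/C=C/C(=O)/C=C(/C=C/c2ccc(O)c(OC)c2)NC2CCCCC2)ccc1O` share one core; compound 3 `CCC(C)NC(=C\C(=O)/C=C/c1ccc(O)cc1)/C=C/c1ccc(O)cc1` and compound 4 `O=C(/C=C(/C=C/c1ccc(O)cc1)NC1CCCCC1)/C=C/c1ccc(O)cc1` share another, which lacks the methoxy groups on the two phenol rings. In a functional assay for inhibition, read by spectrophotometry, with a stated time of 30 min, tested at 1 uM (a higher number here means more inhibition at the concentration tested (going by the name of the read-out), a lower number less inhibition), compound 1 gives 0.13%, compound 2 gives 0.13% and compound 3 gives 0.03%. All three numbers sit at the floor of the read-out, and none of the gaps between them exceeds the scatter of this kind of measurement, so no ordering of compound 1, compound 2 and compound 3 can be read from them.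

The change from compound 1 to compound 2 is cyclohexyl in place of sec-butyl on an amine nitrogen; in this assay it made no change at the digits printed from compound 1 to compound 2 (within the scatter). The difference between the core of compound 1 and the core of compound 3 is not broken down here. The change made from compound 3 to compound 4 is cyclohexyl in place of sec-butyl on an amine nitrogen, the same change as before, at the same kind of amine nitrogen. In this assay the step of a number 0.1 percentage points higher from compound 3 to compound 4 (within the scatter) is expected to be flat, because no change at the digits printed from compound 1 to compound 2 (within the scatter) shows that the same change moved nothing on the other core and because compound 3 at 0.03% already gives a very small number. Compound 4 is accordingly estimated to give 0.1% in this assay, with the range 0% to 6%.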

Compound 4, a percentage reported as inhibition, at one concentration (the size of the read-out at that concentration, not a potency): 0.03%
Estimate against measurement, compound 4: 0.1 percentage points above; measured number inside the range.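

In this assay, cyclohexyl in place of sec-butyl on an amine nitrogen gives no change at the digits printed from compound 3 to compound 4 (within the scatter), and the step reads the same on the two cores: the same change on two cores in this assay, no change at the digits printed (within the scatter) from compound 1 to compound 2 and no change at the digits printed (within the scatter) from compound 3 to compound 4, 0 percentage points apart, within the scatter of two such steps

Within this series, then, the change carries from the core with the methoxy groups to the core without them, at least in the sense that neither step departs from the scatter. All four numbers lie at the floor of the read-out, however, so this agreement shows only that the change leaves each of these compounds at that floor at the single concentration tested; it does not show that the two cores would respond alike if a compound in either series gave a clearly measurable inhibition, and two steps set no rule for any further core.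

The compounds shown leave open whether any other group on the amine nitrogen, such as a benzyl group, a longer chain or a chain ending in a carboxylic acid, would move the number clear of the floor on either core. They also leave open whether a measurable step of this kind would carry from one core to the other.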